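Working notes: clearance and the group on the amine chain

This account rests on a few compounds, and the source may have more. Where it says the series, first, only, none or still open, it means among the compounds named here.

- compound 1 `Fc1ccc([C@]2(CCNCc3cccc(Cl)c3)CCO[C@]3(CCOC3)C2)nc1` gives 29.2 mL/min/kg
- compound 2 `Fc1ccc([C@]2(CCNCc3scc4c3CCC4)CCO[C@]3(CCOC3)C2)nc1` gives 108 mL/min/kg
- compound 3 `Fc1ccc([C@]2(CCNCc3scc4c3CCCC4)CCO[C@]3(CCOC3)C2)nc1` is not yet measured

In an ADME assay on microsomes from liver (Homo sapiens) for metabolic stability, read by LC-MS, using NADPH, with stated times of 10 min and 60 min (on this read-out lower numbers stand for slow clearance and higher numbers for fast clearance), compound 2 stands highest of the two measured compounds at 108 mL/min/kg. Compound 3 differs from compound 2 in one place: a group of 9 heavy atoms (8 carbon, 1 sulfur; one five-membered aromatic ring with 1 hetero atom, one six-membered non-aromatic ring of carbon only) in place of a group of 8 heavy atoms (7 carbon, 1 sulfur; one five-membered non-aromatic ring of carbon only, one five-membered aromatic ring with 1 hetero atom), on a saturated chain carbon bound to an amine nitrogen. Among the measured compounds shown here, the only measured step that bears on this is a 3.7-fold higher number from compound 1 to compound 2 (0.57 log units; beyond the scatter), a modest step beyond the scatter at the same place. That step exchanged a different kind of group, however. Here both groups keep one five-membered aromatic ring with 1 hetero atom, and the non-aromatic ring of carbon only goes from five-membered to six-membered. For the measured compounds named here, no measured pair isolates that change, so no step beyond the scatter is expected in this assay. The expected step is a 1.1-fold higher number from compound 2 to compound 3 (0.03 log units; within the scatter). For compound 3 the estimated clearance is 115 mL/min/kg, with an expected range of 60 mL/min/kg to 210 mL/min/kg.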

Compound 3, clearance: 339 mL/min/kg
Compound 3: the middle estimate sits 2.9-fold (0.47 log units) below what was measured, outside the stated range (above it).
By their numbers in this assay, from the lowest: compound 1; then compound 2; then compound 3.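

In this assay the non-aromatic ring of carbon only going from five-membered to six-membered gives a 3.1-fold higher number from compound 2 to compound 3 (0.50 log units; beyond the scatter) with the five-membered aromatic ring with 1 hetero atom kept, so the number at this place, on a saturated chain carbon bound to an amine nitrogen, answers to that ring alone. Against the group of 7 heavy atoms with one six-membered aromatic ring of carbon only, the same entering group gives a 12-fold higher number from compound 1 to compound 3 (1.06 log units; beyond the scatter) and is the widest gap among these compounds, leaving compound 1 lowest with both of its steps beyond the scatter. No evidence on the cause of either step is at hand.

Open, on these data alone, is whether a seven-membered non-aromatic ring of carbon only would carry the number further up. Also open, as far as these compounds go, is whether a nitrile on the six-membered aromatic ring of carbon only, in place of the chlorine, would hold it near compound 1.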